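A few compounds are considered here, and "the series" means these few. Any claim that something is new, unique, unknown or untested is made for them only; others in the source may bear on it.

In an ADME assay on a cell-free system (plasma, Homo sapiens) for metabolic stability, at 37 degrees C (on this read-out higher numbers stand for a longer-lived compound and lower numbers for a shorter-lived compound), compound 1 (`CCC/N=C1\S/C(=C\c2ccc(C(=O)OC)cc2)C(=O)N1c1ccccc1C`) gives > 3 h, which is a limit of the assay and not a number. Compound 2 (`CCC/N=C1\S/C(=C\c2ccc(C(=O)OCCO)cc2)C(=O)N1c1ccccc1C`) gives > 3 h, again only a limit. Compound 2 therefore stands at the limit of > 3 h in this assay, at which 2 of the 2 values shown sit. Among the measured compounds shown here, the one measured step is a step that the two limits leave unreadable from compound 1 to compound 2, so it offers no size to carry forward.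

Compound 3 (`CCC/N=C1\S/C(=C\c2ccc(C(=O)NCCO)cc2)C(=O)N1c1ccccc1C`) keeps the shared core and changes one place: (2-hydroxyethyl)amino in place of 2-hydroxyethoxy on a carbonyl carbon, ((2-hydroxyethyl)amino in place of 2-hydroxyethoxy on a carbonyl carbon). No measured pair among these compounds contains this exchange, so no step beyond the scatter is expected in this assay, in either direction. The estimated step is a step that the limit leaves unreadable from compound 2 to compound 3. For compound 3 the expected half-life in this assay is 6 h, with an estimated range from 3 h to 24 h.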

Compound 3, half-life in the Homo sapiens assay: > 3 h
Compound 3: no number, only a limit; the forecaster's own chance of this, stated with the estimate: 85%; the middle value is on the limit's open side.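

In the Homo sapiens assay compound 3 gives > 3 h, which is a limit of the assay and not a number. Among the compounds shown here, compound 1 and compound 2 sit at the same limit, so no step among the three can be read. The compounds shown leave open what half-life each actually has, and whether either exchange on the carbonyl carbon changes it.

In a physicochemical assay for solubility, read by nephelometry, measured as kinetic solubility (a higher number here means a more soluble compound, a lower number a less soluble compound), compound 2 gives 110000 nM. In the physicochemical assay compound 3 gives > 250000 nM, which is a limit of the assay and not a number. In the physicochemical assay (2-hydroxyethyl)amino in place of 2-hydroxyethoxy on a carbonyl carbon gives an at least 2.2-fold higher number from compound 2 to compound 3 (0.35 log units; beyond the scatter).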